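From Compound 3 to Compound 4: Adding Chloro

The source may hold more compounds than are shown below. What is called first, only, known or untested is meant among the compounds shown, and "the series" means these compounds.

Compound 3 `O=c1c(/C=C\c2cccnc2)coc2ccccc12` gives no number in an ADME assay on HeLa cells (Homo sapiens) for cytotoxicity, read by XTT assay, with a stated time of 3 days; a lower number here means that less compound is tolerated, a higher number that more compound is tolerated. Its reading of > 200000 nM is a limit of the assay.

The two other measured compounds both carry chloro on the core. Compound 1 `Clc1ccc2c(c1)C=C(/C=C/c1ccncc1)CO2` gives 75000 nM and compound 2 `O=c1c(/C=C/c2ccncc2)coc2ccc(Cl)cc12` gives 150000 nM, two values within the usual scatter of each other.

Compound 4 `O=c1c(/C=C\c2cccnc2)coc2ccc(Cl)cc12` is compound 3 with chloro in place of hydrogen on an aromatic carbon. Among the measured compounds shown here, no measured pair isolates this change, and compound 1 and compound 2 also differ from compound 3 elsewhere in the structure, so the expectation is loose. A modest move toward less compound tolerated is expected in this assay, since the chloro-bearing compound 2 reads 150000 nM. The expected size is an at least 1.5-fold lower number from compound 3 to compound 4 (0.18 log units; that floor lies within the scatter). A reading that again gives only a limit remains possible. For compound 4, the estimated half-maximal cytotoxic concentration is 130000 nM, with an expected range of 65000 nM to 200000 nM.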

Compound 4, half-maximal cytotoxic concentration: 50000 nM
Compound 4: the middle estimate sits 2.6-fold (0.41 log units) above what was measured; the measured number lies below the stated range.
By their numbers in this assay, from the lowest: compounds 4, 1 and 2 (each within the scatter of the next, the first and the last beyond it). At a limit, above all of these: compound 3.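

Among the compounds shown here, this is the first pair that isolates chloro in place of hydrogen on an aromatic carbon of the shared core: in this assay, the change gives an at least 4.0-fold lower number from compound 3 to compound 4 (0.60 log units; beyond the scatter). Compound 1 and compound 2 also carry chloro, but each differs from compound 3 elsewhere in the structure, so neither could separate this change from the others. The step can be read only as a floor, because compound 3 stands at a limit of the assay: the limit of > 200000 nM in this assay, at which 1 of the 4 values shown sits.

As far as these compounds go, whether a fluoro or a methoxy group on this same aromatic carbon would shift the number in the same direction remains open. Also open, from the compounds shown here alone, is whether the step carries over to the cores of compound 1 and compound 2, since neither has a partner without chloro here.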